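Swapping the aromatic group on the sulfonamide of compound 2

This account rests on a few compounds, and the source may have more. Where it says the series, first, only, none or still open, it means among the compounds named here.

Of the compounds shown here, two of a shared core have been measured in a functional assay (plasma) for inhibition, with Oryctolagus cuniculus as the target; on this read-out lower numbers stand for stronger inhibition and higher numbers for weaker inhibition. Compound 1 `O=C(O)CCC/C=C\C[C@H]1[C@@H]2CCC(C2)[C@@H]1NS(=O)(=O)c1ccc(F)cc1` gives 600 nM. Within the data shown here, compound 2 `COc1ccc(S(=O)(=O)N[C@H]2C3CC[C@H](C3)[C@@H]2C/C=C\CCCC(=O)O)cc1` gives 1700 nM, which is the highest of the two numbers and therefore the weaker inhibition; the only recorded step, a 2.8-fold higher number from compound 1 to compound 2 (0.45 log units; beyond the scatter), came from a methoxy in place of fluoro on an aromatic carbon.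

Compound 3 `Cc1cccc(S(=O)(=O)N[C@H]2C3CC[C@H](C3)[C@@H]2C/C=C\CCCC(=O)O)c1` has not yet been measured. It differs from compound 2 in one place: 3-methylphenyl in place of 4-methoxyphenyl on a sulfonyl sulfur. Among the measured compounds shown here, no recorded step matches this change exactly. For the measured compounds named here, the one step that exists concerns the same aromatic group on the sulfonyl sulfur, and it was modest, so there is no ground to expect a large movement in this assay in either direction. A reasonable expectation is a number somewhere between those of compound 1 and compound 2.

For compound 3, the expected value in this assay is 1000 nM, with a range from 400 nM to 3000 nM, which would mean an estimated step of a 1.7-fold lower number from compound 2 to compound 3 (0.23 log units; within the scatter).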

Compound 3, half-maximal inhibitory concentration: 1700 nM
Compound 3: the middle estimate sits 1.7-fold (0.23 log units) below what was measured, within the range that was stated.
By their numbers in this assay, from the lowest: compound 1; then compounds 2 and 3 (each within the scatter of the next).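

Putting 3-methylphenyl in place of 4-methoxyphenyl on a sulfonyl sulfur gives no change at the digits printed from compound 2 to compound 3 (within the scatter) in this assay. This swap takes away the hydrogen-bond acceptor of the group and one heavy atom, and also moves the substituent to a different place on the ring, yet the two compounds cannot be told apart here. Measured against the 4-fluorophenyl group, 3-methylphenyl gives a 2.8-fold higher number from compound 1 to compound 3 (0.45 log units; beyond the scatter) and so matches the earlier step of a 2.8-fold higher number from compound 1 to compound 2 (0.45 log units; beyond the scatter), leaving the 4-fluorophenyl group as the only one of the three that stands apart, while nothing available explains why the other two groups read alike.

On these data alone, what stays open is whether the methyl group and the methoxy group simply make no difference here, since 3-methylphenyl and 4-methoxyphenyl differ in two ways at once, and a 4-methylphenyl or an unsubstituted phenyl group would be needed to pull those apart. As far as these compounds go, it is also open how far the aromatic ring itself matters on the sulfonyl sulfur, which a pyridine ring or a simple alkyl chain in its place could test.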